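The source may hold more compounds than are shown below. What is called first, only, known or untested is meant among the compounds shown, and "the series" means these compounds.

Compound 1 `CC1SC(c2cccc(C(=O)NCCCCc3ccccc3)c2)N(c2ccc(C3CC3)cc2)C1=O` gives 10000 nM as its measured value.
Compound 2 `COc1ccccc1N1C(=O)CSC1c1cc(F)cc(C(=O)NCCCCc2ccccc2)c1` gives 10000 nM as its measured value.

In a physicochemical assay for solubility, read by turbidimetry, measured as kinetic solubility, at pH 6.8 (on this read-out higher numbers stand for higher solubility and lower numbers for lower solubility), compound 2 stands at 10000 nM and is level with compound 1 within the scatter. Compound 3 `C#Cc1cc(C(=O)NCCCCc2ccccc2)cc(C2SCC(=O)N2c2ccccc2OC)c1` differs from compound 2 in one place. The change is ethynyl in place of fluoro on an aromatic carbon and puts ethynyl in place of fluoro on an aromatic carbon, meta to two large groups. For the measured compounds named here, no measured pair differs in a single place, so the data show no size for such a swap. The expected result is a 1.3-fold lower number from compound 2 to compound 3 (0.10 log units; within the scatter) in this assay and no move beyond the scatter. The estimated value for compound 3 is 8000 nM with an expected range from 3000 nM to 15000 nM on this read-out.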

Compound 3, solubility: 10000 nM
For compound 3 the middle estimate is 1.3-fold (0.10 log units) below the measured one; measured number inside the range.
By their numbers in this assay, from the lowest: compounds 1, 2 and 3 (each within the scatter of the next).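

In this assay, for the compounds shown here, ethynyl in place of fluoro on an aromatic carbon, meta to two large groups, gives no change at the digits printed from compound 2 to compound 3 (within the scatter) and is the first step here between compounds that differ in one place. This position therefore now has one measured step, which compounds 1 and 2 alone could not give. Nothing on hand accounts for this result. The compounds shown leave open whether an amine or a carboxylic acid at this position would also stay level with compound 2 in this assay on this read-out.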